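Dropping one trifluoromethyl: from compound 3 to compound 4

A few compounds are considered here, and "the series" means these few. Any claim that something is new, unique, unknown or untested is made for them only; others in the source may bear on it.

Among the compounds with values here, compound 3 `COc1cc(Cl)cc(-c2nn(-c3cccc(NC(=O)Nc4cc(C(F)(F)F)cc(C(F)(F)F)c4)c3)cc2-c2ccncc2)c1` gives 8% in a functional assay on NCI-H23 cells (Homo sapiens) for inhibition, read by sulforhodamine B assay, with a stated time of 48 h, tested at 1 uM (a lower number here means a stronger effect, a higher number a weaker effect of the compound at the concentration tested), the lowest of the three numbers measured so far. Compound 1 `O=C(Nc1cccc(-n2cc(-c3ccncc3)c(-c3cc(O)cc(Cl)c3)n2)c1)Nc1ccc(Cl)c(C(F)(F)F)c1` gives 96% and compound 2 `COc1cc(Cl)cc(-c2nn(-c3cccc(NC(=O)Nc4ccc(Cl)c(C(F)(F)F)c4)c3)cc2-c2ccncc2)c1` gives 60%. Within the data shown here, the only single-place step measured, a number 36 percentage points lower from compound 1 to compound 2 (beyond the scatter), concerns methyl in place of hydrogen on an oxygen on an aromatic ring and does not touch the part altered here. Compound 4 `COc1cc(Cl)cc(-c2nn(-c3cccc(NC(=O)Nc4cccc(C(F)(F)F)c4)c3)cc2-c2ccncc2)c1` differs from compound 3 by hydrogen in place of trifluoromethyl on an aromatic carbon. Among the measured compounds shown here, no measured step bears on this change; compounds 2 and 3 differ in more than one place, so their values show only that compound 3 sits far below compound 2. Compound 4 is therefore expected to lie between those two, at 35% (range 10% to 70%), a step of a number 27 percentage points higher from compound 3 to compound 4 (beyond the scatter).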

Compound 4, a percentage reported as activity, at one concentration (the size of the read-out at that concentration, not a potency): 71%
Compound 4: the middle estimate sits 36 percentage points below what was measured; measured number outside the range, above it.
By their numbers in this assay, from the lowest: compound 3; then compound 2; then compound 4; then compound 1.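

In this assay the effect depends strongly on this aromatic ring's substitution: hydrogen in place of trifluoromethyl gives a number 63 percentage points higher from compound 3 to compound 4 (beyond the scatter), a large loss of effect at the concentration tested. Hydrogen in place of chloro gives a number 11 percentage points higher from compound 2 to compound 4 (beyond the scatter), a modest loss, so compound 4 is weaker than both compounds carrying a second group on that ring. No measurement available here accounts for either step. On these data alone, whether an amine or a carboxylic acid in place of the trifluoromethyl would retain the effect remains open.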